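Urea aryl swap on a piperidinyl pyrimidine core

The compounds below may be only part of what the source reports. "The series", "measured", "known", "first", "only" and "open" are said of these compounds alone.

Measured compounds:
compound 1, `O=C(Nc1ccc(Cl)cc1)Nc1nc(Sc2c[nH]c3ccccc23)cc(N2CCCC2)n1` — 10400 nM
compound 2, `Cc1ccc(C)c(NC(=O)Nc2nc(Sc3c[nH]c4ccccc34)cc(N3CCCCC3)n2)c1` — > 50000 nM

In a functional assay on PC-3 cells (Homo sapiens) for inhibition, with a stated time of 72 h (on this read-out lower numbers stand for stronger inhibition and higher numbers for weaker inhibition), compound 1 gives 10400 nM. Compound 2 reaches only a limit of the assay in this assay, namely > 50000 nM; this is the point noted as the limit of > 50000 nM in this assay, at which 1 of the 2 values shown sits, so compound 2 stands at the weak end of the two numbers shown, without a value of its own. Compound 3, `O=C(Nc1ccc(Cl)cc1)Nc1nc(Sc2c[nH]c3ccccc23)cc(N2CCCCC2)n1`, has not been measured in this assay. It differs from compound 2 in one place: 4-chlorophenyl in place of 2,5-dimethylphenyl on an amide-type nitrogen. Within the data shown here, no measured pair shows this change on its own. Compound 1 carries the same 4-chlorophenyl on the urea nitrogen and gives a value inside the measured range, whereas compound 2 with 2,5-dimethylphenyl does not; on this basis the step from compound 2 to compound 3 is expected to move towards stronger inhibition, though its size cannot be fixed because compound 2 is known only as a limit. The expected step is an at least 2.5-fold lower number from compound 2 to compound 3 (0.39 log units; beyond the scatter). Compound 3 is expected to give about 20000 nM in this assay, within a range from 5000 nM to 80000 nM.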

Compound 3, half-maximal inhibitory concentration: 42500 nM
The estimate for compound 3 lay 2.1-fold (0.33 log units) below the measured number; low and high end bracket the measured number.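

In this assay, among these compounds, the change on the amide-type nitrogen now has a first reading with piperidin-1-yl held fixed, an at least 1.1-fold lower number from compound 2 to compound 3 (0.07 log units; that floor lies within the scatter), which does not establish a real gain for 4-chlorophenyl over 2,5-dimethylphenyl. Compound 2 is known only as a limit, so this step has a floor and no size of its own: the limit of > 50000 nM in this assay, at which 1 of the 3 values shown sits.

The clearer new finding concerns the other site, where 4-chlorophenyl is held fixed and the change on the aromatic carbon is piperidin-1-yl in place of pyrrolidin-1-yl, giving a 4.1-fold higher number from compound 1 to compound 3 (0.61 log units; beyond the scatter); this modest step shows that the group at this place affects the read-out on its own, with pyrrolidin-1-yl the stronger of these two.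

The compounds shown leave open whether morpholin-4-yl or an open-chain dimethylamino group on that aromatic carbon would extend or reverse this difference. They also leave open how a plain phenyl or a 4-fluorophenyl on the amide-type nitrogen would compare with 4-chlorophenyl, and whether 2,5-dimethylphenyl would read differently with pyrrolidin-1-yl on the shared core.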